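Aryl swap on the fused core: outlook for compound 3

The compounds below may be only part of what the source reports. "The series", "measured", "known", "first", "only" and "open" are said of these compounds alone.

Compound 2 `Cc1ccc(-c2nc3sc(Cc4ccc(Cl)cc4)nn3c2Br)cc1` reaches only a limit in a functional assay on HeLa cells (Homo sapiens) for cytotoxicity, with a stated time of 72 h; on this read-out higher numbers stand for weaker inhibition and lower numbers for stronger inhibition: compound 2 gives > 250000 nM, which is a limit of the assay and not a number. Compound 1 `Clc1ccc(Cc2nn3c(Br)c(-c4ccc(Br)cc4)nc3s2)cc1` carries bromo where compound 2 carries methyl; in this assay compound 1 gives 188000 nM. The step of an at least 1.3-fold higher number from compound 1 to compound 2 (0.12 log units; that floor lies within the scatter) is the only measured one in the series, and its floor rests on (the limit of > 250000 nM in this assay, at which 1 of the 2 values shown sits). Compound 3 `Clc1ccc(Cc2nn3c(Br)c(-c4ccc(Cl)cc4Cl)nc3s2)cc1` differs from compound 2 by 2,4-dichlorophenyl in place of 4-methylphenyl on an aromatic carbon. Among the compounds with values here, no measured step covers that kind of change; the single step at hand stays inside the scatter, so no shift beyond the scatter is expected for the move to compound 3, and the limit may well be reached again. The estimate for compound 3 is 200000 nM with a range from 80000 nM to 400000 nM. The expected step of an at least 1.2-fold lower number from compound 2 to compound 3 (0.09 log units; that floor lies within the scatter) is thus essentially flat.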

Compound 3, half-maximal inhibitory concentration: 118000 nM
The estimate for compound 3 lay 1.7-fold (0.23 log units) above the measured number, and the stated range covers the measured number.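

In this assay, the aryl position on the shared core now shows its first step beyond the scatter: an at least 2.1-fold lower number from compound 2 to compound 3 (0.32 log units; beyond the scatter). That step is only a floor and not a sized change, as compound 2 stands at a limit of the assay and not at a number: the limit of > 250000 nM in this assay, at which 1 of the 3 values shown sits. The swap of 4-bromophenyl for 2,4-dichlorophenyl reads a 1.6-fold lower number from compound 1 to compound 3 (0.20 log units; within the scatter), so these two groups are not separated at this position.

From the compounds shown here alone, it remains open whether a single chloro on the phenyl ring would match 2,4-dichlorophenyl, and whether the bromo group on the core has any bearing on these numbers. Also open is what an amine or a carboxylic acid on that phenyl ring would do, and whether any group at this position gives numbers far lower than those shown.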